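The source may report more compounds than this note shows. Statements on the series, on what has been measured and on what is new or still open speak of the compounds shown alone.

Measured compounds:
Compound 1 `CCn1c(C(=O)NCCN)ccc1C(CC)(CC)c1ccc(OCC(O)C(C)(C)C)c(C)c1` — in an assay on HL-60 cells for agonist activity at vitamin D3 receptor (Homo sapiens), read by microscopy, with a stated time of 96 h (on this read-out lower numbers stand for an effect already at smaller amounts and higher numbers for an effect only at larger amounts of compound), compound 1 gives 10 nM
Compound 2 `C=CCN(C)C(=O)c1ccc(C(CC)(CC)c2ccc(OCC(O)C(C)(C)C)c(C)c2)n1CC` — in this assay compound 2 gives 3950 nM

Compound 2 stands at the highest of the two numbers seen so far, its nearest neighbour being compound 1, which lies a long way lower. For the measured compounds named here, the only step measured in this assay is a 400-fold higher number from compound 1 to compound 2 (2.60 log units; beyond the scatter), and it runs through compound 2 itself.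

Compound 3 `CCn1c(C(=O)Nc2ccc(OC(F)(F)F)cc2)ccc1C(CC)(CC)c1ccc(OCC(O)C(C)(C)C)c(C)c1` has not yet been measured. It differs from compound 2 by (4-(trifluoromethoxy)phenyl)amino in place of allyl(methyl)amino on a carbonyl carbon. The entering group brings back 1 hydrogen-bond donor on the amide, as compound 1 had, but the step of a 400-fold higher number from compound 1 to compound 2 (2.60 log units; beyond the scatter) compares compound 2 with an aminoethyl amide, not an aryl amide, so it bears on this change only indirectly. On that ground a step in this assay of a 7.9-fold lower number from compound 2 to compound 3 (0.90 log units; beyond the scatter) is expected, downward, though with wide uncertainty. Compound 3 is estimated at 500 nM, within 50 nM to 5000 nM.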

Compound 3, half-maximal effective concentration: > 50000 nM
Compound 3: a limit, no number (the forecaster's own chance of this, stated with the estimate: 10%); middle value at least 100-fold (2.00 log units) away from the limit.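

In this assay compound 3 gives > 50000 nM, a limit of the assay and not a number. On the carbonyl carbon, the (4-(trifluoromethoxy)phenyl)amino group gives an at least 12-fold higher number from compound 2 to compound 3 (1.10 log units; beyond the scatter), and on the amide-type nitrogen, replacing 2-aminoethyl gives an at least 5000-fold higher number from compound 1 to compound 3 (3.69 log units; beyond the scatter). Compound 3 regains the hydrogen-bond donor that allyl(methyl)amino lacks, yet its number does not move back towards compound 1, so among these compounds the presence of that donor alone does not go with a low number.

The compounds shown leave open whether the aromatic ring or the trifluoromethoxy group goes with the rise, which a plain phenyl or a benzyl amide could separate. They also leave open whether the amine of compound 1 matters, which a 2-hydroxyethyl or a 3-aminopropyl chain could test.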